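Tert-butyl in place of methyl on a urea-linked phenyl ring

The source may hold more compounds than are shown below. What is called first, only, known or untested is meant among the compounds shown, and "the series" means these compounds.

Of the compounds shown here, three of one series have been tested in a functional assay on HepG2 cells (Homo sapiens) for antiproliferative activity, read by MTT assay; on this read-out lower numbers stand for stronger inhibition and higher numbers for weaker inhibition. Compound 1 `COc1ccc(NC(=O)Nc2cccc(CNc3ncnc4ccccc34)c2)cc1` gives a value of > 50000 nM in this assay, which is a limit of the assay rather than a number. Compound 2 `COc1cc2ncnc(NCc3cccc(NC(=O)Nc4ccccc4C)c3)c2cc1OC` likewise gives only the limit > 50000 nM in this assay. Compound 3 `COc1cc2ncnc(NCc3cccc(NC(=O)Nc4ccc(C)cc4)c3)c2cc1OC` also sits at the limit, > 50000 nM in this assay. Within the data shown here, the only step between compounds that differ in one place, from compound 2 to compound 3, reads a step that the two limits leave unreadable from compound 2 to compound 3, so nothing can be read from it about size or direction. All three values share one feature: the limit of > 50000 nM in this assay, at which 3 of the 3 values shown sit.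

Compound 4 `COc1cc2ncnc(NCc3cccc(NC(=O)Nc4ccc(C(C)(C)C)cc4)c3)c2cc1OC` differs from compound 3 by tert-butyl in place of methyl on an aromatic carbon. Among the measured compounds shown here, no measured step bears on this change, and compound 3 itself stands only at a limit, so there is no numeric footing from which a step could be expected. The step from compound 3 to compound 4 is therefore expected to be a step that the limit leaves unreadable from compound 3 to compound 4, which is no more than a guess around the limit. Compound 4 is expected to give about 60000 nM in this assay, within a range from 15000 nM to 200000 nM, and most likely the assay will again report only a limit for compound 4.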

Compound 4, half-maximal inhibitory concentration: 6850 nM
Compound 4: middle estimate off by 8.8-fold (0.94 log units), on the high side, outside the stated range (below it).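

Among these compounds, at this place on the urea-linked phenyl ring the group clearly matters: in this assay, tert-butyl in place of methyl gives an at least 7.2-fold lower number from compound 3 to compound 4 (0.86 log units; beyond the scatter), which the earlier compounds, all held at the limit, could not show. The change also reads against the other methyl compound, as 4-(tert-butyl)phenyl in place of 2-methylphenyl gives an at least 7.2-fold lower number from compound 2 to compound 4 (0.86 log units; beyond the scatter), and each of these two steps has a limit at one end and so gives only a minimum size. Compound 4 is the only compound here whose value is a number rather than a limit: the limit of > 50000 nM in this assay, at which 3 of the 4 values shown sit.

Going by these compounds, the step between the two methyl compounds cannot be read, so whether the place of the methyl on the ring has any effect stays open. Also open, on these data alone, is whether an isopropyl group or a carboxylic acid at this place would give a number in this assay, and whether 4-(tert-butyl)phenyl would do the same on the core of compound 1.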